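This account rests on a few compounds, and the source may have more. Where it says the series, first, only, none or still open, it means among the compounds named here.

Working notes on the acid ceramidase series.

Compound 1 `O=C(NCCCCc1ccccc1)n1c(=O)oc2cc(C3CCOCC3)ccc21` gives 68 nM in an assay on HEK293 cells for inhibition of acid ceramidase (Homo sapiens), read by fluorescence, with stated times of 10 min and 3 h; a lower number here means a stronger inhibitor, a higher number a weaker inhibitor. Among the measured compounds shown here, this is the lowest of the three numbers known so far. Compound 2 `CCOCCNC(=O)n1c(=O)oc2cc(C3CCN(C)CC3)ccc21` gives 1050 nM in this assay, and compound 3 `COCCCNC(=O)n1c(=O)oc2cc(-c3ccc(F)cc3)ccc21` gives 2600 nM; both gaps to compound 1 lie beyond the scatter, so compound 1 is the most potent of the three measured.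

Compound 4 `CN1CCN(c2ccc3c(c2)oc(=O)n3C(=O)NCCCCc2ccccc2)CC1` has not been measured. It differs from compound 1 in one place: 4-methylpiperazin-1-yl in place of oxan-4-yl on an aromatic carbon. For the measured compounds named here, no measured pair isolates this change, so its size is unknown. Since compound 2, which also carries a ring with a methylated nitrogen, gives 1050 nM, some loss seems plausible, and the step from compound 1 to compound 4 is expected to be a 3.2-fold higher number from compound 1 to compound 4 (0.51 log units; beyond the scatter), a modest weakening. Compound 4 is estimated at 220 nM, within 60 nM to 800 nM.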

Compound 4, half-maximal inhibitory concentration: 116 nM
Estimate against measurement, compound 4: 1.9-fold (0.28 log units) above, and the stated range covers the measured number.
By their numbers in this assay, from the lowest: compounds 1 and 4 (each within the scatter of the next); then compound 2; then compound 3.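

The swap of oxan-4-yl for 4-methylpiperazin-1-yl on this aromatic carbon gives a 1.7-fold higher number from compound 1 to compound 4 (0.23 log units; within the scatter) and so does not separate the two rings in this assay. Among the compounds shown here, this is the first single-place reading at this position, and it shows that the position accepts either six-membered ring with the rest of compound 1 unchanged. Nothing available accounts for this result.

Open, on these data alone, is whether an unmethylated piperazin-1-yl, a morpholin-4-yl or an open-chain amine at this position would read the same. For the compounds shown here, also open is whether this swap reads the same with a chain other than the one on compound 1.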